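Swapping a Urea for a Carbamate at Low Exposure

This account rests on a few compounds, and the source may have more. Where it says the series, first, only, none or still open, it means among the compounds named here.

Measured in an ADME assay on the whole organism (plasma, Rattus norvegicus, strain Sprague-Dawley) for pharmacokinetics, read by LC-MS, with a stated time of 4 h, at a dose of 15 mg/kg by the intraduodenal route; on this read-out higher numbers stand for higher exposure at the dose given and lower numbers for lower exposure:
- Compound 1 `C=C[C@@H]1C[C@]1(NC(=O)[C@@H]1C[C@@H](Oc2nccc3cc(OC)ccc23)CN1C(=O)[C@@H](NC(=O)NC(C)(C)C)C(C)(C)C)C(=O)NS(=O)(=O)C1CC1`: 497 ng.h/mL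
- Compound 2 `C=C[C@@H]1C[C@]1(NC(=O)[C@@H]1C[C@@H](Oc2nccc3cc(OC)ccc23)CN1C(=O)[C@@H](NC(=O)N[C@H](C(=O)N1CCN(c2ncccn2)CC1)C(C)(C)C)C(C)(C)C)C(=O)NS(=O)(=O)C1CC1`: 1630 ng.h/mL
- Compound 3 `C=C[C@@H]1C[C@]1(NC(=O)[C@@H]1C[C@@H](Oc2cc(-c3ccccc3)nc3cc(OC)ccc23)CN1C(=O)[C@@H](NC(=O)NC(C)(C)C)C(C)(C)C)C(=O)NS(=O)(=O)C1CC1`: 17 ng.h/mL

Compound 3 stands lowest of the three, beyond the scatter from both other compounds. Compound 4 `C=C[C@@H]1C[C@]1(NC(=O)[C@@H]1C[C@@H](Oc2cc(-c3ccccc3)nc3cc(OC)ccc23)CN1C(=O)[C@@H](OC(=O)NC(C)(C)C)C(C)(C)C)C(=O)NS(=O)(=O)C1CC1` carries ((tert-butyl)carbamoyl)oxy in place of ((tert-butyl)carbamoyl)amino on a saturated chain carbon bound to a carbonyl carbon and a saturated chain carbon. Going by the values given here, no measured pair isolates this change, so the data offer no direct guide. A modest rise, little beyond the scatter, is expected in this assay. The expected change is a 2.4-fold higher number from compound 3 to compound 4 (0.37 log units; beyond the scatter). For compound 4 the estimated value is 40 ng.h/mL, with an expected range from 10 ng.h/mL to 160 ng.h/mL.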

Compound 4, area under the concentration-time curve: 82 ng.h/mL
Beside the measured number, compound 4's estimate is 2.1-fold (0.31 log units) below it; the range from low to high includes it.
By their numbers in this assay, from the lowest: compound 3; then compound 4; then compound 1; then compound 2.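

On a saturated chain carbon bound to a carbonyl carbon and a saturated chain carbon, ((tert-butyl)carbamoyl)oxy in place of ((tert-butyl)carbamoyl)amino gives a 4.8-fold higher number from compound 3 to compound 4 (0.68 log units; beyond the scatter) in this assay. This is the first change in a single place shown here, and it shows that this one exchange can move exposure beyond the scatter. Nothing available here accounts for the rise.

On these data alone, it remains open whether the same exchange would raise exposure on the core of compound 1. Also open, as far as these compounds go, is how a methylene group in place of the oxygen would compare.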